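Fluoro for amino on the shared core: likely still inactive

A few compounds are considered here, and "the series" means these few. Any claim that something is new, unique, unknown or untested is made for them only; others in the source may bear on it.

Within the data shown here, compound 1 `CC(=O)OC(C)n1cnc2c(Cl)nc(N)nc21` is one of two compounds measured in a functional assay on SW-620 cells (Homo sapiens) for inhibition; a higher number here means a weaker inhibitor, a lower number a stronger inhibitor. In this assay compound 1 gives only a limit, > 500000 nM, so no number is known for it. Among the measured compounds shown here, compound 2 `CC(O)n1cnc2c(N)nc(I)nc21` differs from compound 1 in more than one place, and no single step between them is drawn. In this assay compound 2 likewise gives only a limit, > 500000 nM. Taken together the two values show nothing more than the limit of > 500000 nM in this assay, at which 2 of the 2 values shown sit, and no ordering between compound 1 and compound 2 can be read from them.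

Compound 3 `CC(=O)OC(C)n1cnc2c(Cl)nc(F)nc21` has not been measured in this assay. It differs from compound 1 by fluoro in place of amino on an aromatic carbon. For the measured compounds named here, no measured step offers a reference for this change, and with compound 1 itself at the limit there is no number to move from. The expected step in this assay is a step that the limit leaves unreadable from compound 1 to compound 3, none beyond the scatter, with compound 3 expected to remain at the limit. For compound 3 the estimate in this assay is 600000 nM, within 100000 nM to 5000000 nM.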

Compound 3, half-maximal inhibitory concentration: 8900 nM
The estimate for compound 3 lay 67-fold (1.83 log units) above the measured number, and the stated range ends above it.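

In this assay, replacing amino with fluoro on the aromatic carbon between two ring nitrogen atoms gives an at least 56-fold lower number from compound 1 to compound 3 (1.74 log units; beyond the scatter), which shows that the group at this position can decide whether the shared core reads out as a number at all. On these data alone, the full size of this change remains unknown, as the step starts from a limit and not from a measured value for its starting compound. Compound 3 is the only compound in the series with a number, and it gives the series its first reference point, where the earlier compounds offered none: the limit of > 500000 nM in this assay, at which 2 of the 3 values shown sit.

The compounds shown do not separate an effect of adding fluoro from an effect of removing amino, and a methoxy group or a second chloro group at this position would help to tell these apart. As far as these compounds go, whether the chloro group and the ester on the side chain contribute to the activity of compound 3 also stays open, and a comparison with the free hydroxyl of compound 2 cannot settle this, as compound 2 differs from compound 3 in more than one place.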